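This account rests on a few compounds, and the source may have more. Where it says the series, first, only, none or still open, it means among the compounds named here.

Compound 1 `O=C(Nc1ccccc1)c1cnc(NCc2c(F)ccc3c2CCO3)n2cnnc12`: < 1000 nM
Compound 2 `Cc1ncccc1-c1cnc(NCc2c(F)ccc3c2CCO3)c2n[nH]c(=O)n12`: < 2000 nM
Compound 3 `Cc1ncccc1-c1cnc(NCc2c(F)ccc3c2CCO3)c2cn[nH]c(=O)c12`: < 2000 nM

In a physicochemical assay for solubility, read by LC-MS, in phosphate buffer, with a stated time of 24 h, at pH 7.4 (on this read-out higher numbers stand for higher solubility and lower numbers for lower solubility), compound 1 gives < 1000 nM, which is a limit of the assay and not a number, so that compound 1 stands at the limit of < 1000 nM in this assay, at which 1 of the 3 values shown sits. In this assay compound 2 gives < 2000 nM, again a limit. In this assay compound 3 gives < 2000 nM, likewise a limit, so that compounds 2 and 3 sit at the limit of < 2000 nM in this assay, at which 2 of the 3 values shown sit. Going by the values given here, no step between measured compounds can be counted from these limits. Compound 4 `C[C@H]1CC(=O)N(c2cnc(NCc3c(F)ccc4c3CCO4)n3cnnc23)C1` differs from compound 1 by 4-methyl-2-oxopyrrolidin-1-yl in place of phenylcarbamoyl on an aromatic carbon. With only limits to rest on, the step from compound 1 to compound 4 is expected to be an at least 5.0-fold higher number from compound 1 to compound 4 (0.69 log units; beyond the scatter), towards higher solubility. Compound 4 is therefore estimated at 5000 nM, in a range from 500 nM to 50000 nM.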

Compound 4, solubility: 200000 nM
Beside the measured number, compound 4's estimate is 40-fold (1.60 log units) below it; measured number above the stated range.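

In this assay, going by these compounds alone, compound 4 gives 200000 nM as the first number in this set that is not a limit. The result is an at least 200-fold higher number from compound 1 to compound 4 (2.30 log units; beyond the scatter) with 4-methyl-2-oxopyrrolidin-1-yl in place of phenylcarbamoyl on this aromatic carbon, so the read-out is far from indifferent to what this position carries. Compound 1 stands at a limit of the assay, so the step is a floor only: the limit of < 1000 nM in this assay, at which 1 of the 4 values shown sits.

The compounds shown leave open which part of the change carries the step, the departing carbon-only aromatic ring or the departing hydrogen-bond donor. Going by these compounds, whether a morpholine or a carboxylic acid on this carbon would do the same also stays open.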